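The source may hold more compounds than are shown below. What is called first, only, known or untested is meant among the compounds shown, and "the series" means these compounds.

Working notes on the series. Compound 1 `O=C(COCc1ncccn1)N1CCN(c2ccc(Cl)cc2Cl)CC1` gives 18000 nM in a functional assay on HEK293 cells for positive allosteric modulation of metabotropic glutamate receptor 5 (Homo sapiens), read by FLIPR and calcium flux; on this read-out lower numbers stand for an effect already at smaller amounts and higher numbers for an effect only at larger amounts of compound. Compound 2 `O=C(COCc1nccs1)N1CCN(c2ccc(Cl)cc2Cl)CC1` carries the same core and in this assay gives 10300 nM. Among the measured compounds shown here, the one step measured so far, a 1.7-fold lower number from compound 1 to compound 2 (0.24 log units; within the scatter), exchanges one aromatic heterocycle for another at the same place, and its size does not separate the two numbers; compound 2 therefore cannot be set apart from compound 1 on what has been measured.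

Compound 3 `O=C(COCc1cccs1)N1CCN(c2ccc(Cl)cc2Cl)CC1` is the next member. Its difference from compound 2 is thiophen-2-yl in place of 1,3-thiazol-2-yl on a saturated chain carbon bound to an oxygen on a saturated carbon. For the measured compounds named here, the only step that bears on this change is a 1.7-fold lower number from compound 1 to compound 2 (0.24 log units; within the scatter): a heterocycle swap at the same attachment point that stayed within the scatter. Nothing measured in the series points to a step in either direction for compound 3 in this assay, so none beyond the scatter is expected.

Compound 3 is accordingly expected to give 10000 nM in this assay, with a range from 4000 nM to 25000 nM. The step this estimate implies from compound 2 to compound 3, a 1.0-fold lower number from compound 2 to compound 3 (0.01 log units; within the scatter), is expected to lie within the scatter.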

Compound 3, half-maximal effective concentration: > 310 nM
Compound 3: only a limit was reported (the forecaster's own chance of this, stated with the estimate: 15%); the middle value lies beyond the limit too.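

Compound 3 is reported only as a limit, not as a number: the limit of > 310 nM in this assay, at which 1 of the 3 values shown sits. Among the compounds shown here, no step from compound 1 or compound 2 to compound 3 can be read from this result. The compounds shown leave open whether thiophen-2-yl in place of 1,3-thiazol-2-yl or pyrimidin-2-yl at this place changes the number at all, and in which direction.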